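The source may hold more compounds than are shown below. What is called first, only, known or untested is meant among the compounds shown, and "the series" means these compounds.

Working notes on the series.

Compound 1 `CC(C)(C)OC(=O)N1CCC(CCCOc2ccc3c(c2)CCS3(=O)=O)CC1` gives in a functional assay on CHO-K1 cells for agonist activity at Glucose-dependent insulinotropic receptor (Homo sapiens), read by HTRF and cAMP accumulation, with a stated time of 30 min (a lower number here means that less compound is needed, a higher number that more compound is needed for the effect), a value of 736 nM. Compound 2 `CCc1cnc(N2CCC(CCCNc3ccc4c(c3)OCC4=O)CC2)nc1` gives in this assay a value of 117 nM. Compound 3 `CC(C)c1noc(N2CCC(CCCNc3ccc4c(c3)OCC4=O)CC2)n1` gives in this assay a value of 73 nM. Compound 3 thus has the lowest of the three numbers: compound 2 is the nearest and lies within the scatter of it, while compound 1 is the farthest, a gap beyond the scatter. The step of a 1.6-fold lower number from compound 2 to compound 3 (0.20 log units; within the scatter) shows that exchanging one heteroaryl group on the ring amine nitrogen for another shifted the number only within the scatter.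

Compound 4 `CC(C)c1nsc(N2CCC(CCCNc3ccc4c(c3)OCC4=O)CC2)n1` differs from compound 3 in that (3-isopropyl-1,2,4-thiadiazol-5-yl in place of 3-isopropyl-1,2,4-oxadiazol-5-yl on an amine nitrogen in a ring). The entering group matches the leaving one in its counted heavy atoms, donors and acceptors; only the oxygen of the five-membered aromatic ring is replaced by sulfur. Within the data shown here, the single measured step that bears on this change is a 1.6-fold lower number from compound 2 to compound 3 (0.20 log units; within the scatter), a swap at the same position that stayed within the scatter; no measured pair tests an oxygen-for-sulfur exchange directly. The expected step in this assay is therefore one not beyond the scatter, with no direction claimed, a 1.1-fold lower number from compound 3 to compound 4 (0.05 log units; within the scatter). Compound 4 is expected to give about 65 nM, with a range from 25 nM to 170 nM.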

Compound 4, half-maximal effective concentration: 121 nM
Compound 4: the middle estimate sits 1.9-fold (0.27 log units) below what was measured; the measured number falls inside the stated range.
By their numbers in this assay, from the lowest: compounds 3, 2 and 4 (each within the scatter of the next); then compound 1.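

Among these compounds, the oxygen-for-sulfur exchange in the five-membered aromatic ring, which leaves the counted heavy atoms, donors and acceptors unchanged, gives in this assay a 1.7-fold higher number from compound 3 to compound 4 (0.22 log units; within the scatter), the first direct reading of this exchange at this position. Set against 5-ethylpyrimidin-2-yl, the thiadiazole gives a 1.0-fold higher number from compound 2 to compound 4 (0.01 log units; within the scatter), so 5-ethylpyrimidin-2-yl, 3-isopropyl-1,2,4-oxadiazol-5-yl and 3-isopropyl-1,2,4-thiadiazol-5-yl, on an amine nitrogen in a ring, all lie within the scatter of one another, and the series shows no separation among these three groups. No measurement at hand offers a reason for the size of these steps.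

The compounds shown do not tell how a cyclopropyl or a tert-butyl group in place of the isopropyl on the five-membered aromatic ring would read, nor whether a group without an aromatic ring, such as an amide carbonyl, would hold the number at this position. Compound 1 differs from the others in more than one place, so the gap to it cannot be assigned to any single group.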